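Taking the last fluoro off compound 2

The compounds below may be only part of what the source reports. "The series", "measured", "known", "first", "only" and "open" are said of these compounds alone.

In a functional assay on the whole organism with Mus musculus as the target (a higher number here means that more compound is needed for the effect, a lower number that less compound is needed), compound 1 `Cn1nc(-c2ccc(F)cc2F)n(C)c1=S` gives 1 mg/kg and compound 2 `Cn1nc(-c2ccc(F)cc2)n(C)c1=S` gives 0.61 mg/kg. Compound 3 `Cn1nc(-c2ccc(Cl)cc2Cl)n(C)c1=S` gives only a limit, > 25 mg/kg. That leaves compound 2 with one of just two actual numbers, and its nearest neighbour is compound 1, within the scatter of repeated measurements.

The next compound to test is compound 4 `Cn1nc(-c2ccccc2)n(C)c1=S`, which has hydrogen in place of fluoro on an aromatic carbon of compound 2: hydrogen in place of fluoro on an aromatic carbon.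

One measured step involves the same kind of change, hydrogen in place of fluoro on an aromatic carbon, though at another place on the ring. That step is a 1.6-fold lower number from compound 1 to compound 2 (0.21 log units; within the scatter), so it gives no reason to expect a large shift in this assay. A single step is thin evidence, however, so the range has to stay wide.

The expected change is a 1.3-fold higher number from compound 2 to compound 4 (0.12 log units; within the scatter), with no clear direction beyond the scatter. For compound 4 the estimated value is 0.8 mg/kg, with an expected range from 0.25 mg/kg to 3 mg/kg.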

Compound 4, dose for half-maximal effect: 0.15 mg/kg
Compound 4: the middle estimate sits 5.3-fold (0.73 log units) above what was measured; measured number below the stated range.
By their numbers in this assay, from the lowest: compound 4; then compounds 2 and 1 (each within the scatter of the next). At a limit, above all of these: compound 3.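

In this assay, putting hydrogen in place of the fluoro that sits para to a group of 8 heavy atoms gives a 4.1-fold lower number from compound 2 to compound 4 (0.61 log units; beyond the scatter), a change that can be told apart from the scatter. The same kind of change at another place on the ring gave a 1.6-fold lower number from compound 1 to compound 2 (0.21 log units; within the scatter), so of these two steps only the new one shows that removing a fluoro can move this number. Nothing measured here bears on why this step turned out as it did.

What a methoxy group or an amine would do at this place stays open, as the compounds shown carry only hydrogen, fluoro or chloro there. Compound 3 carries two chloro groups and its value of > 25 mg/kg is a limit, so it cannot tell what a lone chloro at this place would do.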